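Swapping a propyl chain for phenyl on the shared core

This account rests on a few compounds, and the source may have more. Where it says the series, first, only, none or still open, it means among the compounds named here.

For the measured compounds named here, compound 1, `CCCc1cc(-c2cn([C@H]3C[C@H](OC(C)=O)[C@@H](COC(C)=O)O3)c(=O)[nH]c2=O)on1`, has the higher of the two numbers measured so far. In a functional assay on PC-3 cells (Homo sapiens) for cytotoxicity, read by sulforhodamine B assay, tested at 10 uM (a higher number here means more inhibition at the concentration tested (going by the name of the read-out), a lower number less inhibition), compound 1 gives 88.1%. Going by the values given here, its only measured neighbour is compound 2, `CC(=O)OC[C@H]1O[C@@H](n2cc(-c3cc(-c4ccc(C(C)(C)C)cc4)no3)c(=O)[nH]c2=O)C[C@@H]1OC(C)=O`, which in this assay gives 27.5%. Among the compounds with values here, the one step between them, a number 60.6 percentage points lower from compound 1 to compound 2 (beyond the scatter), is the sole guide to what a change at this carbon of the core can do.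

Compound 3, `CC(=O)OC[C@H]1O[C@@H](n2cc(-c3cc(-c4ccccc4)no3)c(=O)[nH]c2=O)C[C@@H]1OC(C)=O`, has not yet been measured. It differs from compound 1 by phenyl in place of propyl on an aromatic carbon. The phenyl group is smaller than the 4-(tert-butyl)phenyl group of compound 2 but larger than the propyl chain of compound 1, so it sits between the two measured compounds in the size of the group at this position.

Within the data shown here, only the step from compound 1 to compound 2 bears on this change, and it was large. A drop is therefore expected, probably smaller than that one. The estimated step in this assay is a number 38.1 percentage points lower from compound 1 to compound 3 (beyond the scatter). Compound 3 is expected to show about 50%, within a range from 22% to 78%.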

Compound 3, a percentage reported as inhibition, at one concentration (the size of the read-out at that concentration, not a potency): 85.5%
The estimate for compound 3 lay 35.5 percentage points below the measured number; the whole stated range lies below it.
By their numbers in this assay, from the lowest: compound 2; then compounds 3 and 1 (each within the scatter of the next).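

In this assay, the exchange of 3-propyl-1,2-oxazol-5-yl for 3-phenyl-1,2-oxazol-5-yl gives a number 2.6 percentage points lower from compound 1 to compound 3 (within the scatter) and so leaves the read-out unchanged within the usual scatter, showing that an aromatic ring at this carbon can take the place of the propyl chain without a measurable loss. The large drop seen earlier therefore cannot be attributed to the phenyl ring itself, since the step with hydrogen in place of tert-butyl on an aromatic carbon gives a number 58 percentage points higher from compound 2 to compound 3 (beyond the scatter) and ties that drop to the tert-butyl group among these compounds. Nothing reported alongside these numbers accounts for the effect of the tert-butyl group.

The compounds shown leave open whether a smaller group on the phenyl ring, such as methyl or chlorine, would keep the number close to that of compound 3 or would already lower it, and so where the loss begins between hydrogen and tert-butyl. As far as these compounds go, it also remains open how a saturated ring such as cyclohexyl, or a chain carrying an amine or a carboxylic acid, would behave at this carbon of the shared core.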